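The source may report more compounds than this note shows. Statements on the series, on what has been measured and on what is new or still open speak of the compounds shown alone.

The measured compounds in an in vitro functional assay on HEK293 cells for antagonist activity at melanin-concentrating hormone receptor 1 (Homo sapiens) (a lower number here means a smaller maximal response, a higher number a larger maximal response), are:
compound 1, `Cc1ccc(CN2CCC(NC(=O)NCc3ccc(-c4ccc(F)cc4)cc3)CC2)cc1`, giving 105%
compound 2, `Cc1ccc(CN2CCC(NC(=O)NCc3ccc(-c4ccccc4)cc3)CC2)cc1`, giving 124%
compound 3, `CCC(CO)(CO)NC(=O)N(CCC1CCN(Cc2ccc(C)cc2)CC1)Cc1ccc(-c2ccc(F)cc2)cc1`, giving 111%

Compound 1 and compound 2 differ in one place: hydrogen in place of fluoro on an aromatic carbon. That change gave a number 19 percentage points higher from compound 1 to compound 2 (beyond the scatter). Compound 3 rests on another core, and the difference between the two cores is not broken down here; its value sits within the scatter of compound 1 and beyond the scatter of compound 2. Compound 4, `CCC(CO)(CO)NC(=O)N(CCC1CCN(Cc2ccc(C)cc2)CC1)Cc1ccc(-c2ccccc2)cc1`, has not yet been measured in this assay. It differs from compound 3 by hydrogen in place of fluoro on an aromatic carbon, the same change that separates compound 1 from compound 2, at the same place on the ring. Going by the values given here, on the single earlier case, the step is expected to be a number 14 percentage points higher from compound 3 to compound 4 (beyond the scatter), because the one precedent gave a number 19 percentage points higher from compound 1 to compound 2 (beyond the scatter). Compound 4 is therefore expected to reach 125%, between 105% and 145%.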

Compound 4, largest response reached (reported as Imax), in percent of the reference or control that the assay uses: 93.5%
Compound 4: the middle estimate sits 31.5 percentage points above what was measured, and the stated range ends above it.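

Going from 4-fluorophenyl to phenyl gave, in this assay, a number 17.5 percentage points lower from compound 3 to compound 4 (beyond the scatter). The change therefore did not carry over from one core to the other, and the two steps run in opposite directions: the same change on two cores in this assay, a number 19 percentage points higher (beyond the scatter) from compound 1 to compound 2 and a number 17.5 percentage points lower (beyond the scatter) from compound 3 to compound 4, 36.5 percentage points apart, beyond the scatter of two such steps

This shows that, in these two pairs, the outcome of removing the fluoro group depends on the core that carries it, but it does not show which feature of the cores is responsible, and two pairs set no rule for the series.

On these data alone, it remains open which of the differences between the two cores goes with this reversal. Also open, as far as these compounds go, is how a chloro or a methoxy group in the same place on the ring would read on each core.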